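The source may hold more compounds than are shown below. What is called first, only, known or untested is meant among the compounds shown, and "the series" means these compounds.

Of the compounds shown here, three built on one shared core have been measured, and a fourth waits for its number. Compound 1 `COc1cc(-c2nn(-c3cccc(NC(=O)Nc4cc(C(F)(F)F)cc(C(F)(F)F)c4)c3)cc2-c2ccncc2)ccc1Cl` carries a urea whose far ring bears two trifluoromethyl groups; in a functional assay on MDA-MB-468 cells (Homo sapiens) for inhibition, read by sulforhodamine B assay, with a stated time of 48 h (on this read-out higher numbers stand for weaker inhibition of growth and lower numbers for stronger inhibition of growth), compound 1 gives 1540 nM. Compound 2 `COc1cc(-c2nn(-c3cccc(NC(=O)Nc4cccc(C(F)(F)F)c4)c3)cc2-c2ccncc2)ccc1Cl` keeps one trifluoromethyl on that ring, and compound 2 gives 2160 nM; the step of a 1.4-fold higher number from compound 1 to compound 2 (0.15 log units; within the scatter) is small. Compound 3 `COc1cc(-c2nn(-c3cccc(NC(=O)c4ccc(Cl)c(C(F)(F)F)c4)c3)cc2-c2ccncc2)ccc1Cl` replaces the urea by an amide. For compound 3 the assay reports only a limit, > 32500 nM, so its true value is not known beyond that bound. Within the data shown here, the step of an at least 15-fold higher number from compound 2 to compound 3 (1.17 log units; beyond the scatter) is therefore large, and compound 3 stands at the weak end of the three, the one value that sits at the limit, as the limit of > 32500 nM in this assay, at which 1 of the 3 values shown sits, records.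

Compound 4 `COc1cc(-c2nn(-c3cccc(NC(=O)c4ccccc4)c3)cc2-c2ccncc2)ccc1Cl` is the next variation: phenyl in place of 4-chloro-3-(trifluoromethyl)phenyl on a carbonyl carbon. The measured step that resembles it most is the removal of a trifluoromethyl from the far ring, from compound 1 to compound 2, which stayed within the scatter, whereas the change of urea to amide, from compound 2 to compound 3, cost far more. Since compound 4 keeps the amide of compound 3, only a small movement is expected, a step that the limit leaves unreadable from compound 3 to compound 4, with compound 4 estimated at 40000 nM, between 12000 nM and 120000 nM.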

Compound 4, concentration for total growth inhibition: 3420 nM
The estimate for compound 4 lay 12-fold (1.07 log units) above the measured number, and the stated range ends above it.
By their numbers in this assay, from the lowest: compounds 1, 2 and 4 (each within the scatter of the next, the first and the last beyond it). At a limit, above all of these: compound 3.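

In this assay, phenyl in place of 4-chloro-3-(trifluoromethyl)phenyl on a carbonyl carbon brings an at least 9.5-fold lower number from compound 3 to compound 4 (0.97 log units; beyond the scatter), which shows that an amide at this place can keep growth inhibition when the far ring carries neither chlorine nor trifluoromethyl. The value of compound 3 is a limit and not a number: the limit of > 32500 nM in this assay, at which 1 of the 4 values shown sits. Set against the urea, the amide with a plain phenyl gives a 1.6-fold higher number from compound 2 to compound 4 (0.20 log units; within the scatter), which means that the large loss seen at compound 3 cannot be laid on the amide alone and depends on the far ring that the amide carries.

The compounds shown do not separate the chlorine from the trifluoromethyl on that ring, so it stays open whether one of them alone would bring the same loss, or whether the loss needs both together. As far as these compounds go, it also stays open how the amide series would respond to a far ring bearing a different kind of group, such as an amine or a carboxylic acid, in place of the plain phenyl of compound 4.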